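Furan-2-yl in place of thiophen-3-yl on compound 3

The compounds below may be only part of what the source reports. "The series", "measured", "known", "first", "only" and "open" are said of these compounds alone.

In a functional assay on MCF7 cells (Homo sapiens) for inhibition, with a stated time of 96 h (on this read-out lower numbers stand for stronger inhibition and higher numbers for weaker inhibition), compound 1 (`COc1cc(C(=O)c2cn(-c3cccc(C)c3)cc2-c2ccsc2)cc(OC)c1OC`) gives 65 nM, compound 2 (`COc1cc(C(=O)c2cn(-c3cccc(C)c3)cc2-c2ccco2)cc(OC)c1OC`) gives 23 nM, and compound 3 (`COc1cc(C(=O)c2cn(-c3ccc(C)cc3)cc2-c2ccsc2)cc(OC)c1OC`) gives 4 nM, the lowest of the three numbers. Compound 4 (`COc1cc(C(=O)c2cn(-c3ccc(C)cc3)cc2-c2ccco2)cc(OC)c1OC`) keeps the 4-methylphenyl group of compound 3 but carries furan-2-yl in place of thiophen-3-yl on an aromatic carbon. The same swap, made with 3-methylphenyl on the aromatic nitrogen, gave a 2.8-fold lower number from compound 1 to compound 2 (0.45 log units; beyond the scatter), a modest step. Among the compounds with values here, changing only that methylphenyl group gave a 16-fold lower number from compound 1 to compound 3 (1.21 log units; beyond the scatter), a large step, so the swap may not carry over in full. The expected step in this assay is a 2.0-fold lower number from compound 3 to compound 4 (0.30 log units; within the scatter), in the same direction but smaller. For compound 4 the estimated value is 2 nM, with an expected range from 0.7 nM to 6 nM.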

Compound 4, half-maximal inhibitory concentration: 22 nM
Estimate against measurement, compound 4: 11-fold (1.04 log units) below; the whole stated range lies below it.
By their numbers in this assay, from the lowest: compound 3; then compounds 4 and 2 (each within the scatter of the next); then compound 1.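

With 4-methylphenyl on the ring nitrogen, furan-2-yl in place of thiophen-3-yl gives a 5.5-fold higher number from compound 3 to compound 4 (0.74 log units; beyond the scatter), so the swap reverses direction between the two methylphenyl groups: the same change on two cores in this assay, a 2.8-fold lower number (0.45 log units; beyond the scatter) from compound 1 to compound 2 and a 5.5-fold higher number (0.74 log units; beyond the scatter) from compound 3 to compound 4, 16-fold (1.19 log units) apart, beyond the scatter of two such steps. With furan-2-yl in place, moving the methyl group gives a 1.0-fold lower number from compound 2 to compound 4 (0.02 log units; within the scatter), so the large drop seen with thiophen-3-yl does not appear: the same change on two cores in this assay, a 16-fold lower number (1.21 log units; beyond the scatter) from compound 1 to compound 3 and a 1.0-fold lower number (0.02 log units; within the scatter) from compound 2 to compound 4, 16-fold (1.19 log units) apart, beyond the scatter of two such steps. The two places therefore do not act independently, and among these compounds, only compound 3 pairs thiophen-3-yl with 4-methylphenyl.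

As far as these compounds go, whether this dependence extends to other groups at this position, such as phenyl or an amine, remains open. These compounds also cannot say what links the two places.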